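The source may report more compounds than this note shows. Statements on the series, on what has been measured and on what is new or still open speak of the compounds shown alone.

Measured so far in an assay on THP-1 cells for inhibition of nuclear factor NF-kappa-B complex (Homo sapiens), with stated times of 2 h and 16 h; on this read-out lower numbers stand for stronger inhibition and higher numbers for weaker inhibition:
- compound 1 `CC(C)(C)CCOc1cccc(O)c1C(=O)/C=C/c1ccc(O)cc1`: 3000 nM
- compound 2 `O=C(/C=C/c1ccc(O)cc1)c1c(O)cccc1OCC1CCCC1`: 13000 nM

Among the measured compounds shown here, compound 2 holds the higher of the two numbers; the one step in the pair, a 4.3-fold higher number from compound 1 to compound 2 (0.64 log units; beyond the scatter), separates it from compound 1. Compound 3 `CC(C)COc1cccc(O)c1C(=O)/C=C/c1ccc(O)cc1` differs from compound 2 by isopropyl in place of cyclopentyl on a saturated chain carbon bound to an oxygen on an aromatic ring. For the measured compounds named here, the only measured step at this position, a 4.3-fold higher number from compound 1 to compound 2 (0.64 log units; beyond the scatter), went from an acyclic branched group to the ring and raised the number; compound 3 returns to an acyclic branched group, so a move back toward compound 1 is expected, though one step cannot fix its size. Compound 3 is estimated at 6000 nM (range 2000 nM to 20000 nM), an expected 2.2-fold lower number from compound 2 to compound 3 (0.34 log units; beyond the scatter).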

Compound 3, half-maximal inhibitory concentration: 8000 nM
The estimate for compound 3 lay 1.3-fold (0.12 log units) below the measured number; the measured number falls inside the stated range.
By their numbers in this assay, from the lowest: compound 1; then compounds 3 and 2 (each within the scatter of the next).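

In this assay, isobutoxy in place of cyclopentylmethoxy gives a 1.6-fold lower number from compound 2 to compound 3 (0.21 log units; within the scatter), so the ring and the acyclic group are not told apart at this position. Isopropyl in place of neopentyl gives a 2.7-fold higher number from compound 1 to compound 3 (0.43 log units; beyond the scatter), so compound 1 stands apart from compound 3 as well as from compound 2, and an acyclic group alone does not carry its number. Nothing available explains these differences.

Still open, from the compounds shown here alone, is whether a longer chain, or an amine or carboxylic acid on the chain, would take the number below that of compound 1.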